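Trading a hydroxy group for trifluoromethyl on the piperidine

The source may hold more compounds than are shown below. What is called first, only, known or untested is meant among the compounds shown, and "the series" means these compounds.

Compound 2 `CCN(CC)S(=O)(=O)c1ccc(S(=O)(=O)N2CCC[C@@H](C(=O)N3CCC(O)CC3)C2)cc1` gives the highest of the three numbers in a functional assay on MIA PaCa-2 cells (Homo sapiens) for inhibition, read by MTT assay, with a stated time of 7 days (on this read-out lower numbers stand for stronger inhibition and higher numbers for weaker inhibition), namely 870 nM. Its nearest neighbour is compound 1 `O=C([C@@H]1CCCN(S(=O)(=O)c2ccc(S(=O)(=O)N3CC[C@@H](O)C3)cc2)C1)N1CCC(F)(F)CC1`, which in this assay gives 210 nM, and the furthest is compound 3 `CCC(CC)S(=O)(=O)c1ccc(S(=O)(=O)N2CCC[C@@H](C(=O)N3CCC(F)(F)CC3)C2)cc1`, which in this assay gives 13 nM. Among the compounds with values here, the one single-point step among the measured compounds is a 16-fold lower number from compound 1 to compound 3 (1.21 log units; beyond the scatter), a change on the sulfonyl sulfur rather than on the amide-side ring.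

Compound 4 `CCN(CC)S(=O)(=O)c1ccc(S(=O)(=O)N2CCC[C@@H](C(=O)N3CCC(C(F)(F)F)CC3)C2)cc1` differs from compound 2 by trifluoromethyl in place of hydroxy on a saturated ring carbon. Within the data shown here, no measured step touches this position in isolation: compound 1 and compound 3 both carry a difluoro group on that ring but also differ from compound 2 on the sulfonyl sulfur, so their lower numbers cannot be attributed to the ring alone. Because compound 1 reaches 210 nM and compound 3 reaches 13 nM while compound 2 sits at 870 nM, a modest move toward lower numbers is expected, with wide uncertainty. Compound 4 is therefore estimated at 350 nM, within 90 nM to 1400 nM, an expected step of a 2.5-fold lower number from compound 2 to compound 4 (0.40 log units; beyond the scatter).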

Compound 4, half-maximal inhibitory concentration: 320 nM
For compound 4 the middle estimate is 1.1-fold (0.04 log units) above the measured one; measured number inside the range.
By their numbers in this assay, from the lowest: compound 3; then compounds 1 and 4 (each within the scatter of the next); then compound 2.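

Within the data shown here, with the sulfonyl side held constant, trifluoromethyl in place of hydroxy gives a 2.7-fold lower number from compound 2 to compound 4 (0.43 log units; beyond the scatter) in this assay and so isolates this ring carbon for the first time, free of any change on the sulfonyl sulfur. The step is modest but beyond the scatter, and the number falls even though the hydroxy's hydrogen-bond donor and acceptor leave and the entering group has neither, so the hydroxy is not needed for activity on this read-out. Nothing shown here gives a measured reason for the step.

The compounds shown leave open whether the same change keeps its size with pentan-3-yl on the sulfonyl sulfur. They also leave open how an amine or a carboxylic acid on this ring carbon would read.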